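This account rests on a few compounds, and the source may have more. Where it says the series, first, only, none or still open, it means among the compounds named here.

For the measured compounds named here, in a functional assay on KB cells (Homo sapiens) for cytotoxicity (a lower number here means that less compound is needed, a higher number that more compound is needed for the effect), three compounds have values so far.
Compound 1 `COC1=C(C)C(=O)/C(=C(O)/C=C/c2ccc(OC)cc2)C(=O)C1(C)C` gives 2.9 ug/mL
Compound 2 `COC1=C(C)C(=O)/C(=C(O)/C=C/c2ccc(O)cc2)C(=O)C1(C)C` gives 3 ug/mL
Compound 3 `COC1=C(C)C(=O)/C(=C(O)/C=C/c2ccc(C)cc2)C(=O)C1(C)C` gives 1.9 ug/mL

Compound 3 at 1.9 ug/mL stands within the scatter of the other two, as a 1.5-fold lower number from compound 1 to compound 3 (0.18 log units; within the scatter) and a 1.6-fold lower number from compound 2 to compound 3 (0.20 log units; within the scatter) show. Compound 4 `COC1=C(C)C(=O)/C(=C(O)/C=C/c2ccccc2C)C(=O)C1(C)C` has the same atoms joined differently, and 2-methylphenyl in place of 4-methylphenyl on a double-bonded chain carbon bound to a double-bonded chain carbon sums up the change, 2-methylphenyl in place of 4-methylphenyl on a double-bonded chain carbon bound to a double-bonded chain carbon. Those two steps and a 1.0-fold higher number from compound 1 to compound 2 (0.01 log units; within the scatter) are the nearest evidence, and all are within the scatter. As far as these compounds go, each swaps one group, and none moves a group, so this change is untested. The expected step in this assay is a 1.2-fold higher number from compound 3 to compound 4 (0.08 log units; within the scatter) and thus nothing beyond the scatter. Compound 4 is expected at 2.3 ug/mL with an estimated range from 1.1 ug/mL to 4.6 ug/mL around that figure.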

Compound 4, concentration for half-maximal effect: 1.6 ug/mL
Estimate against measurement, compound 4: 1.4-fold (0.16 log units) above; low and high end bracket the measured number.
By their numbers in this assay, from the lowest: compounds 4, 3, 1 and 2 (each within the scatter of the next).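

In this assay, moving the methyl group, with 2-methylphenyl in place of 4-methylphenyl, gives a 1.2-fold lower number from compound 3 to compound 4 (0.07 log units; within the scatter) and so leaves the number within the scatter. The larger swaps also stay within the scatter, with a 1.9-fold lower number from compound 2 to compound 4 (0.27 log units; within the scatter) and a 1.8-fold lower number from compound 1 to compound 4 (0.26 log units; within the scatter), so these four phenyl groups cannot be told apart in this assay. Nothing available explains this result. As far as these compounds go, whether an amine or a carboxylic acid in place of the methyl of 2-methylphenyl would carry the number beyond the scatter remains open.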